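The compounds below may be only part of what the source reports. "The series", "measured", "known", "first", "only" and "open" are said of these compounds alone.

Measured in a functional assay on MCF7 cells (Homo sapiens) for antiproliferative activity, read by MTT assay, with a stated time of 48 h; on this read-out lower numbers stand for stronger inhibition and higher numbers for weaker inhibition:
- compound 1 `C=C(c1cc(OC)c(OC)c(OC)c1)c1ccc(OC)cc1NC(=O)CO`: 110 nM
- compound 2 `C=C(c1cc(OC)c(OC)c(OC)c1)c1ccc(OC)cc1NC(=O)CNC`: 240 nM
- compound 3 `C=C(c1ccc2c(c1)C=CC(C)(C)O2)c1ccc(OC)cc1NC(=O)CN(C)C`: 940 nM

Compound 2 stands in the middle of these three numbers, with compound 1 lower and compound 3 higher. Compound 4 `C=C(c1cc(OC)c(OC)c(OC)c1)c1ccc(OC)cc1NC(=O)CN(C)C` has not yet been measured. It differs from compound 2 by a single change, methyl in place of hydrogen on an amine nitrogen, which turns methylamino into dimethylamino.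

Within the data shown here, only one measured step involves this side chain: a 2.2-fold higher number from compound 1 to compound 2 (0.34 log units; beyond the scatter). That modest step swapped hydroxy for methylamino, which is a different change, so it is only an indirect guide. Compound 3 also carries dimethylamino and gives 940 nM, but its core differs, so it is a loose guide as well. The addition of one methyl is therefore expected to produce no step beyond the scatter in this assay, and the expected step is a 1.3-fold higher number from compound 2 to compound 4 (0.10 log units; within the scatter). For compound 4 the estimated value is 300 nM, with an expected range of 110 nM to 800 nM.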

Compound 4, half-maximal inhibitory concentration: 390 nM
Estimate against measurement, compound 4: 1.3-fold (0.11 log units) below; measured number inside the range.
By their numbers in this assay, from the lowest: compound 1; then compounds 2 and 4 (each within the scatter of the next); then compound 3.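

In this assay, putting a methyl in place of hydrogen on the amine nitrogen gives a 1.6-fold higher number from compound 2 to compound 4 (0.21 log units; within the scatter), so this side chain tolerates the change from methylamino to dimethylamino without a step that can be told from the scatter. Measured against the hydroxy of compound 1, dimethylamino gives a 3.5-fold higher number from compound 1 to compound 4 (0.55 log units; beyond the scatter), a modest step in the same direction as the one for methylamino, a 2.2-fold higher number from compound 1 to compound 2 (0.34 log units; beyond the scatter). No measurement is available that would explain these numbers.

The compounds shown leave open how the side chain would read with a plain amino group, with two hydrogens on the nitrogen, or with the nitrogen inside a piperidine ring. They also leave open what a longer chain carrying the same dimethylamino group would do.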